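The source may report more compounds than this note shows. Statements on the series, on what has been measured and on what is new or still open speak of the compounds shown alone.

Compound 1 `CCC1C(=O)N(C)c2cnc(-n3ccc4cc(C(=O)NC)ccc43)nc2N1c1ccn(C)n1`: 43100 nM
Compound 2 `CC[C@@H]1C(=O)N(C)c2cnc(Nc3ccc(S(N)(=O)=O)cc3)nc2N1C1CCCC1`: 3390 nM
Compound 3 `CCC1C(=O)N(C)c2cnc(Nc3ccc(S(=O)(=O)NCC(C)C)cc3)nc2N1c1ccn(C)n1`: 31600 nM

All three were tested in a functional assay on A549 cells (Homo sapiens) for antiproliferative activity, read by CCK-8 assay, with a stated time of 72 h; a lower number here means a stronger inhibitor of growth, a higher number a weaker inhibitor of growth. Compound 1 has the highest number of the three. Compound 3 lies close to it, within the usual scatter, so no order between compound 1 and compound 3 can be claimed. Compound 2 sits far lower than compound 1, a gap beyond the scatter, so compound 2 is the stronger growth inhibitor of that pair.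

Compound 4 `CCC1C(=O)N(C)c2cnc(-n3ccc4cc(C(=O)NC(C)C)ccc43)nc2N1c1ccn(C)n1` differs from compound 1 in one place: isopropyl in place of methyl on an amide-type nitrogen. For the measured compounds named here, no measured pair shows this change, so its effect is unknown here. The step from compound 1 to compound 4 is expected to be a 1.2-fold lower number from compound 1 to compound 4 (0.09 log units; within the scatter), not beyond the scatter in either direction. Compound 4 is therefore estimated at 35000 nM, within a range from 12000 nM to 100000 nM.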

Compound 4, concentration for 50% growth inhibition: 22000 nM
The estimate for compound 4 lay 1.6-fold (0.20 log units) above the measured number; the range from low to high includes it.
By their numbers in this assay, from the lowest: compound 2; then compounds 4, 3 and 1 (each within the scatter of the next).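

In this assay, for the compounds shown here, the first comparison of compounds that differ in one place is a 2.0-fold lower number from compound 1 to compound 4 (0.29 log units; within the scatter) for isopropyl in place of methyl on the amide-type nitrogen. At this position, then, the swap from methylcarbamoyl to isopropylcarbamoyl shows no change that can be told from the scatter. No measurement here offers an explanation for this result.

As far as these compounds go, whether a longer chain, a cyclopentyl ring or a chain carrying an amine on this nitrogen would move the number beyond the scatter remains open.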